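The compounds below may be only part of what the source reports. "The series", "measured", "known", "first", "only" and "open" are said of these compounds alone.

Two compounds share one core. Compound 1, `O=c1c2ccccc2[se]n1-c1nc(SCc2ccccc2)n[nH]1`, and compound 2, `Cc1ccc(CSc2n[nH]c(-n3[se]c4ccccc4c3=O)n2)cc1`, differ only by a methyl group on an aromatic carbon. In a functional assay on A549 cells (Homo sapiens) for antiproliferative activity, read by CCK-8 assay, with a stated time of 48 h (on this read-out higher numbers stand for weaker inhibition and lower numbers for stronger inhibition), compound 1 gives > 50000 nM, which is a limit of the assay and not a number. In this assay compound 2 gives > 50000 nM, also a limit rather than a number, so compound 2 stands at the edge of what the assay can report. Among the measured compounds shown here, the single step between measured compounds, a step that the two limits leave unreadable from compound 1 to compound 2, cannot be sized, since (the limit of > 50000 nM in this assay, at which 2 of the 2 values shown sit). Compound 3, `O=c1c2ccccc2[se]n1-c1nc(SCc2ccc([N+](=O)[O-])cc2)n[nH]1`, has not been measured. It differs from compound 2 by nitro in place of methyl on an aromatic carbon. For the measured compounds named here, no measured step involves a nitro group, and the only step available is unreadable, so no direction beyond the scatter can be expected. Compound 3 is therefore expected to give 50000 nM in this assay, within 20000 nM to 120000 nM, most likely again reported only as a limit. The expected step of a number no higher from compound 2 to compound 3 (the limit leaves the size open) is accordingly none beyond the scatter.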

Compound 3, half-maximal inhibitory concentration: 9140 nM
Compound 3: middle estimate off by 5.5-fold (0.74 log units), on the high side; the whole stated range lies above it.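

Nitro at this position, on the six-membered aromatic ring of carbon only and para to a large group, is the first change shown to move the result in this assay, with an at least 5.4-fold lower number from compound 2 to compound 3 (0.73 log units; beyond the scatter). Nitro in place of hydrogen gives the same kind of gain, with an at least 5.4-fold lower number from compound 1 to compound 3 (0.73 log units; beyond the scatter), so compound 3 is the only compound here that yields a real number and not a limit. Both steps give only a minimum size, and the step between compound 1 and compound 2 cannot be read, because those two compounds sit at a limit: the limit of > 50000 nM in this assay, at which 2 of the 3 values shown sit.

Going by these compounds, whether nitro is special at this position stays open, and an amine or a carboxylic acid at the same place would help to show that. The compounds shown also do not reveal why nitro has this effect.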